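From trifluoromethyl to fluoro: an expected solubility step

A few compounds are considered here, and "the series" means these few. Any claim that something is new, unique, unknown or untested is made for them only; others in the source may bear on it.

Measured so far in a physicochemical assay for solubility, read by spectrophotometry, in phosphate buffer, with a stated time of 18 h, at pH 7.4 (a lower number here means a less soluble compound, a higher number a more soluble compound), as solubility
compound 1 `CCc1ccc(-c2nc3c(c(C)nn3-c3ccccc3)c(-c3ccccc3O)c2C#N)cc1` gives 3100 nM
compound 2 `Cc1nn(-c2ccccc2)c2nc(-c3ccc(C(F)(F)F)cc3)c(C#N)c(-c3ccccc3O)c12` gives 3500 nM

Compound 2 stands level with compound 1 on these numbers. Among the measured compounds shown here, the only measured step is a 1.1-fold higher number from compound 1 to compound 2 (0.05 log units; within the scatter) and it came with trifluoromethyl in place of ethyl on an aromatic carbon. Compound 3 `Cc1nn(-c2ccccc2)c2nc(-c3ccc(F)cc3)c(C#N)c(-c3ccccc3O)c12` carries fluoro in place of trifluoromethyl on an aromatic carbon, para to a large group, a change counted as fluoro in place of trifluoromethyl on an aromatic carbon in full. For the measured compounds named here, the one measured step bears on this change only in part, as it touched the same aromatic carbon but no measured compound carries fluoro there. With that step inside the scatter, nothing beyond the scatter is expected in this assay in either direction. The estimated change is a 1.0-fold higher number from compound 2 to compound 3 (0.01 log units; within the scatter) and no more than that. Compound 3 is expected at 3600 nM with a range from 1800 nM to 7000 nM in this measurement.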

Compound 3, solubility: 6000 nM
Beside the measured number, compound 3's estimate is 1.7-fold (0.22 log units) below it, within the range that was stated.
By their numbers in this assay, from the lowest: compounds 1, 2 and 3 (each within the scatter of the next).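

Among the compounds shown here, compound 3 gives the first reading for fluoro at this aromatic carbon, para to a large group. In this assay, the exchange of trifluoromethyl for fluoro gives a 1.7-fold higher number from compound 2 to compound 3 (0.23 log units; within the scatter), and the exchange of ethyl for fluoro gives a 1.9-fold higher number from compound 1 to compound 3 (0.29 log units; within the scatter), so ethyl, trifluoromethyl and fluoro all stay within the scatter of one another here, even though the group that leaves in the step to compound 3 has four heavy atoms and the one that enters has one. No supporting measurement explains these numbers.

As far as these compounds go, whether an amine, a carboxylic acid or a longer chain at this carbon would take the number beyond the scatter remains open. Also open, from the compounds shown here alone, is whether the exchange of trifluoromethyl for fluoro would read the same with a different group elsewhere on the shared core, which stays unchanged in all three compounds.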